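A few compounds are considered here, and "the series" means these few. Any claim that something is new, unique, unknown or untested is made for them only; others in the source may bear on it.

Measured so far in an assay on cells for agonist activity at ecdysone receptor (Bombyx mori), read by a luciferase reporter, with a stated time of 24 h; on this read-out lower numbers stand for an effect already at smaller amounts and higher numbers for an effect only at larger amounts of compound:
Compound 1, `Cc1ccccc1C(=O)NN(C(=O)c1ccccc1Cl)C(C)(C)C`: 72.4 nM
Compound 2, `CC(C)(C)N(NC(=O)c1cccc(Br)c1)C(=O)c1ccccc1Cl`: 191 nM
Compound 3, `CC(C)(C)N(NC(=O)c1ccc(Cl)cc1)C(=O)c1ccccc1Cl`: 115 nM

Compound 3 stands second highest of the three numbers; its nearest neighbour is compound 1, with a 1.6-fold higher number from compound 1 to compound 3 (0.20 log units; within the scatter), and its furthest is compound 2, with a 1.7-fold lower number from compound 2 to compound 3 (0.22 log units; within the scatter). Both of these steps are within the scatter, so no order among compound 1, compound 3 and compound 2 can be read from them. Only a 2.6-fold higher number from compound 1 to compound 2 (0.42 log units; beyond the scatter) lies beyond the scatter, and that one is modest.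

Compound 4, `CCc1ccc(C(=O)NN(C(=O)c2ccccc2Cl)C(C)(C)C)cc1`, differs from compound 3 by ethyl in place of chloro on an aromatic carbon. Among the compounds with values here, no measured pair alters this single position; the three measured steps each exchange one whole aryl group for another on the same carbonyl carbon, and the largest of them is a 2.6-fold higher number from compound 1 to compound 2 (0.42 log units; beyond the scatter). On that showing, compound 4 is expected in this assay to move little from compound 3, with a 1.4-fold lower number from compound 3 to compound 4 (0.13 log units; within the scatter) as the estimated step, not beyond the scatter. The estimate for compound 4 in this assay is 85 nM, with a range from 30 nM to 250 nM.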

Compound 4, half-maximal effective concentration: 5.75 nM
Compound 4: middle estimate off by 15-fold (1.17 log units), on the high side; measured number outside the range, below it.
By their numbers in this assay, from the lowest: compound 4; then compounds 1, 3 and 2 (each within the scatter of the next, the first and the last beyond it).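

Working in this assay, the group at this one position, para to a large group, matters far more than the earlier compounds suggested: a swap from chloro to ethyl, only one heavy atom more, gives a 20-fold lower number from compound 3 to compound 4 (1.30 log units; beyond the scatter). The largest step among the earlier aryl exchanges was a 2.6-fold higher number from compound 1 to compound 2 (0.42 log units; beyond the scatter), whereas 4-ethylphenyl separates clearly from both other aryl groups, with a 33-fold lower number from compound 2 to compound 4 (1.52 log units; beyond the scatter) and also a 13-fold lower number from compound 1 to compound 4 (1.10 log units; beyond the scatter). The data at hand offer no explanation for this jump.

A single ethyl compound cannot show whether the gain peaks at ethyl or continues with a propyl or longer chain, or how a methyl, isopropyl or methoxy group at the same position would compare. Also open, from the compounds shown here alone, is whether the gain persists when the aryl group on the other carbonyl changes.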